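Swapping One Ring on the Shared Core

The compounds below may be only part of what the source reports. "The series", "measured", "known", "first", "only" and "open" are said of these compounds alone.

Values in a functional assay on VCaP cells (Homo sapiens) for antiproliferative activity, read by CCK-8 assay, with a stated time of 6 days; a higher number here means a weaker inhibitor, a lower number a stronger inhibitor:
- Compound 1 `CCN(c1ccc(C#N)c(Cl)c1)c1cc(-c2ccccc2)ccc1C`: > 30000 nM, which is a limit and not a number
- Compound 2 `CCN(c1ccc(C#N)c(Cl)c1)c1cc(-c2ccnn2C)ccc1C`: 1670 nM
- Compound 3 `CCN(c1ccc(C#N)c(Cl)c1)c1cc(C2=CCCCC2)ccc1C`: 20000 nM

Going by the values given here, of the two exact numbers, the one for compound 3 is the higher, with a 12-fold higher number from compound 2 to compound 3 (1.08 log units; beyond the scatter). Compound 4 `CCN(c1ccc(C#N)c(Cl)c1)c1cc(-c2ccoc2)ccc1C` carries furan-3-yl in place of cyclohex-1-en-1-yl (furan-3-yl in place of cyclohex-1-en-1-yl on an aromatic carbon). The closest guide is 1-methyl-1H-pyrazol-5-yl, another aromatic ring with hetero atoms, which gave an at least 17-fold lower number from compound 1 to compound 2 (1.25 log units; beyond the scatter). Phenyl in compound 1 warns that an aromatic ring alone is not enough, so only part of that gain is expected. The expected change is a 4.0-fold lower number from compound 3 to compound 4 (0.60 log units; beyond the scatter). For compound 4 the estimate is 5000 nM, with an expected range of 1500 nM to 20000 nM.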

Compound 4, half-maximal inhibitory concentration: 4010 nM
Compound 4: the middle estimate sits 1.2-fold (0.10 log units) above what was measured, and the stated range covers the measured number.
By their numbers in this assay, from the lowest: compound 2; then compound 4; then compound 3. At a limit, above all of these: compound 1.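

Furan-3-yl shows that the gain at this position is not confined to 1-methyl-1H-pyrazol-5-yl: in this assay there is a 5.0-fold lower number from compound 3 to compound 4 (0.70 log units; beyond the scatter) on leaving cyclohex-1-en-1-yl, and an at least 7.4-fold lower number from compound 1 to compound 4 (0.87 log units; beyond the scatter) on leaving phenyl. The furan still falls short of the pyrazole, with a 2.4-fold higher number from compound 2 to compound 4 (0.38 log units; beyond the scatter) when furan-3-yl takes the place of 1-methyl-1H-pyrazol-5-yl. The step from compound 1 is only a floor, as its value is a limit and not a number: the limit of > 30000 nM in this assay, at which 1 of the 4 values shown sits.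

Which feature of these two rings sets them apart remains open. So does what an amine or a carboxylic acid would do on this aromatic carbon.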